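Swapping the Fluorophenyl Arm for a Cyanophenyl

The source may report more compounds than this note shows. Statements on the series, on what has been measured and on what is new or still open speak of the compounds shown alone.

Measured so far:
compound 1 `O=C(O)c1ccccc1-c1ccc(CCc2ncc(Cc3ccccc3F)[nH]2)cc1` — 177 nM
compound 2 `O=C(O)c1ccccc1-c1ccc(CCc2ncc(CC3CCOCC3)[nH]2)cc1` — 338 nM
compound 3 `CC(C)(C)Cc1cnc(CCc2ccc(-c3ccccc3C(=O)O)cc2)[nH]1` — 106 nM

All three share one core and differ only in the group on a saturated chain carbon bound to an aromatic carbon. In an in vitro functional assay on cells for agonist activity at Bombesin receptor subtype-3 (Homo sapiens), read by luminescence and calcium flux (on this read-out higher numbers stand for an effect only at larger amounts of compound and lower numbers for an effect already at smaller amounts), compound 1 gives 177 nM, compound 2 gives 338 nM and compound 3 gives 106 nM. Compound 1 sits in the middle of these numbers: the nearest is compound 3 with a 1.7-fold lower number from compound 1 to compound 3 (0.22 log units; within the scatter), the furthest is compound 2 with a 1.9-fold higher number from compound 1 to compound 2 (0.28 log units; within the scatter), and both of those steps are within the scatter. Only between compound 2 and compound 3 is there a real difference, a 3.2-fold lower number from compound 2 to compound 3 (0.50 log units; beyond the scatter), a modest one.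

Compound 4 `N#Cc1ccc(Cc2cnc(CCc3ccc(-c4ccccc4C(=O)O)cc3)[nH]2)cc1` has not yet been measured. It differs from compound 1 by 4-cyanophenyl in place of 2-fluorophenyl on a saturated chain carbon bound to an aromatic carbon. Among the compounds with values here, the steps that bear on this are the two replacements at the same position, from compound 1 to compound 2 and from compound 1 to compound 3, neither of which reached beyond the scatter. Within the data shown here, no measured step exchanges one aromatic ring for another, so there is no direct guide. The step to compound 4 is expected to be a 1.1-fold higher number from compound 1 to compound 4 (0.05 log units; within the scatter), within the scatter. Compound 4 is therefore estimated at 200 nM, with a range from 80 nM to 500 nM.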

Compound 4, half-maximal effective concentration: 5890 nM
The estimate for compound 4 lay 29-fold (1.47 log units) below the measured number, outside the stated range (above it).
By their numbers in this assay, from the lowest: compounds 3, 1 and 2 (each within the scatter of the next, the first and the last beyond it); then compound 4.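

This position tolerates less than the first three compounds suggested: the 2-fluorophenyl, oxan-4-yl and tert-butyl groups differ by a modest amount at most, yet in this assay the 4-cyanophenyl group gives a 33-fold higher number from compound 1 to compound 4 (1.52 log units; beyond the scatter), a 56-fold higher number from compound 3 to compound 4 (1.74 log units; beyond the scatter) and a 17-fold higher number from compound 2 to compound 4 (1.24 log units; beyond the scatter). Compound 1 and compound 4 both carry a six-membered aromatic ring of carbon only at this place, so such a ring by itself does not keep the number low. Nothing available here explains the jump.

The step from 2-fluorophenyl to 4-cyanophenyl changes both the attached group and its place on the ring, and these compounds cannot separate the two. A plain phenyl group here would show how the bare ring behaves, without either fluorine or nitrile.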